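A few compounds are considered here, and "the series" means these few. Any claim that something is new, unique, unknown or untested is made for them only; others in the source may bear on it.

Working notes on the series. Of the compounds shown here, two have numbers so far. Compound 1 `O=C1CC(c2ccccc2Cl)CN1c1ccc2c(c1)CCNCC2` carries a lactam ring with a chlorinated phenyl group; compound 2 `O=C1OC(c2ccccc2)CN1c1ccc2c(c1)CCNCC2` carries an oxazolidinone ring with an unsubstituted phenyl group on the same shared core. In an assay on CHO-K1 cells for displacement of a labelled ligand from 5-hydroxytryptamine receptor 6 (Homo sapiens), read by scintillation counting, with a stated time of 3 h (a lower number here means a stronger inhibitor, a higher number a weaker inhibitor), compound 1 gives 100 nM, and in this assay compound 2 gives 16 nM. Compound 2 therefore stands at the lower of the two numbers, and the gap to compound 1 is beyond the scatter. The two compounds differ in more than one place, so the pair says nothing about either change on its own.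

Compound 3 `O=C1OC(c2cccc(Cl)c2)CN1c1ccc2c(c1)CCNCC2` is not yet measured. Its difference from compound 2 is chloro in place of hydrogen on an aromatic carbon, meta to a large group. Within the data shown here, no measured pair isolates this change. A halogen added to the phenyl ring of this kind of series is expected to leave the number close to where it stands or lower it modestly, so the step from compound 2 to compound 3 is estimated as a 1.3-fold lower number from compound 2 to compound 3 (0.12 log units; within the scatter), within or near the scatter. Compound 3 is expected to give 12 nM in this assay, with a range from 4 nM to 40 nM.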

Compound 3, inhibition constant: 10 nM
Beside the measured number, compound 3's estimate is 1.2-fold (0.08 log units) above it; low and high end bracket the measured number.
By their numbers in this assay, from the lowest: compounds 3 and 2 (each within the scatter of the next); then compound 1.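

In this assay, among these compounds, the change from phenyl to 3-chlorophenyl gives a 1.6-fold lower number from compound 2 to compound 3 (0.20 log units; within the scatter), and this is the first pair that differs in one place only. It shows that a chloro group on this aromatic carbon, meta to a large group, is accepted on the oxazolidinone compounds, with the numbers of the pair not separable beyond the scatter. No measurement shown here gives a reason for this result, and the pair supports no statement about what the chlorine does.

On these data alone, whether this place accepts groups other than chloro, such as a methoxy group, an amine or a carboxylic acid, remains open, as does whether the tolerance seen for chloro extends to anything larger. The lactam ring of compound 1 also remains unseparated from the oxazolidinone ring of compound 2 and compound 3, since no pair shown isolates that ring change from the difference in the phenyl group.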